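The compounds below may be only part of what the source reports. "The series", "measured", "known", "first", "only" and "open" are said of these compounds alone.

Working notes on the series. Within the data shown here, the three measured members share one core, seen in compound 1 `Nc1ccc(S(=O)(=O)Nc2ccnc3cc(C(F)(F)F)ccc23)cc1`, compound 2 `N=C(N)NS(=O)(=O)c1ccc(N/C(S)=N\c2ccnc3cc(C(F)(F)F)ccc23)cc1` and compound 3 `O=S(=O)(Nc1nccs1)c1ccc(N/C(S)=N\c2ccnc3cc(C(F)(F)F)ccc23)cc1`, and differ at the sulfonamide nitrogen and in the link to the core. In a functional assay on HeLa cells (Homo sapiens) for antiproliferative activity, read by sulforhodamine B assay, with a stated time of 48 h (a higher number here means a weaker inhibitor, a lower number a stronger inhibitor), compound 1 gives 46000 nM, compound 2 gives 23900 nM and compound 3 gives 95200 nM. Compound 3 therefore holds the highest number of the three; its nearest neighbour is compound 1, its furthest is compound 2. Among the measured compounds shown here, the one step that changes only the sulfonamide nitrogen substituent, a 4.0-fold higher number from compound 2 to compound 3 (0.60 log units; beyond the scatter), is modest and points to a higher number.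

Compound 4 `COc1ncnc(NS(=O)(=O)c2ccc(N/C(S)=N\c3ccnc4cc(C(F)(F)F)ccc34)cc2)c1OC` is not yet measured. It differs from compound 3 by 5,6-dimethoxypyrimidin-4-yl in place of 1,3-thiazol-2-yl on a sulfonamide nitrogen. For the measured compounds named here, only the step from compound 2 to compound 3 bears on this position, and it was modest; no measured pair shows a six-membered aromatic ring on this nitrogen, so the direction is open. The expectation in this assay is a step for compound 4 of about a 1.4-fold lower number from compound 3 to compound 4 (0.13 log units; within the scatter), not clearly beyond the scatter. Compound 4 is thus estimated at 70000 nM, within a range of 22000 nM to 220000 nM.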

Compound 4, half-maximal inhibitory concentration: "not active" (no number reported)
No number was reported for compound 4, so the estimate cannot be set against anything.
By their numbers in this assay, from the lowest: compounds 2 and 1 (each within the scatter of the next); then compound 3.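

In this assay, among these compounds, compound 4 is reported as "not active" with no number, so no step from compound 3 to compound 4 can be read. No evidence at hand bears on this result. The compounds shown leave open how far 5,6-dimethoxypyrimidin-4-yl on a sulfonamide nitrogen separates from 1,3-thiazol-2-yl in numbers.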